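Compound 3 to compound 4: a step among limits

The source may report more compounds than this note shows. Statements on the series, on what has been measured and on what is new or still open speak of the compounds shown alone.

In an ADME assay on Vero cells (Chlorocebus sabaeus) for cytotoxicity, read by neutral red uptake, with a stated time of 48 h (a higher number here means a weaker inhibitor, a lower number a stronger inhibitor), compound 3 `Clc1ccc2c(NCCCn3cnc4c(N5CCCCCC5)nc(Cl)nc43)ccnc2c1` gives only a limit of > 10100 nM and no number. Compound 1 `CN(C)c1nc(Cl)nc2c1ncn2CCCNc1ccnc2cc(Cl)ccc12` likewise gives only a limit, recorded as > 11400 nM in this assay here. Compound 2 `CCN(CC)c1nc(Cl)nc2c1ncn2CCCNc1ccnc2cc(Cl)ccc12` also gives only a limit, recorded as > 10700 nM in the same read-out. All three values are limits, so compound 3 has no rank among them.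

The change to compound 4 `CN1CCN(c2nc(Cl)nc3c2ncn3CCCNc2ccnc3cc(Cl)ccc23)CC1` is 4-methylpiperazin-1-yl in place of azepan-1-yl on an aromatic carbon. The measured steps that bear on it are exchanges at that same place: a step that the two limits leave unreadable from compound 1 to compound 2, a step that the two limits leave unreadable from compound 1 to compound 3 and a step that the two limits leave unreadable from compound 2 to compound 3. None of the three has a readable size, and 4-methylpiperazin-1-yl has no value yet.

No step beyond the scatter is therefore expected in this assay. Among the compounds with values here, this expectation rests on compound 3, whose limit of > 10100 nM is the only anchor for the step. The expected step is a number no higher from compound 3 to compound 4 (the limit leaves the size open), an estimate of no real change. For compound 4 the expected value is 10000 nM, with an estimated range from 4000 nM to 20000 nM, and another limit is the likelier report.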

Compound 4, half-maximal inhibitory concentration: > 10100 nM
Compound 4 gave a limit, no number; the forecaster's own chance of this, stated with the estimate: 70%; middle value at least 1.0-fold (0.00 log units) away from the limit.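

In this assay compound 4 gives > 10100 nM, a limit and not a number. Within the data shown here, compound 1, compound 2 and compound 3 also stand as limits, so no step from any of them to compound 4 can be read. The compounds shown leave open whether the four groups at this place differ in this read-out at all.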